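A few compounds are considered here, and "the series" means these few. Any claim that something is new, unique, unknown or untested is made for them only; others in the source may bear on it.

Compound 1 `CC(C)N(Cc1ccc(C(=O)NO)cc1)S(=O)(=O)c1c(F)c(F)c(F)c(F)c1F` gives 440 nM
Compound 2 `CC(C)CN(Cc1ccc(C(=O)NO)cc1)S(=O)(=O)c1cc(F)c(F)c(F)c1F` gives 690 nM
Compound 3 `CC(C)N(Cc1ccc(C(=O)NO)cn1)S(=O)(=O)c1cc(F)c(F)c(F)c1F` gives 1600 nM

All three values come from a functional assay on MM1.S cells (Homo sapiens) for inhibition, with a stated time of 72 h (a lower number here means a stronger inhibitor, a higher number a weaker inhibitor), and no two of these compounds differ in one place only. Compound 2 lies within the scatter of compound 1. Compound 3 is the weaker of the pair formed with compound 2, and that gap lies beyond the scatter.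

Compound 4 `O=C(NO)c1ccc(CN(C2CCCC2)S(=O)(=O)c2cc(F)c(F)c(F)c2F)cc1` is still to be measured and shares the core of compound 2. The change is cyclopentyl in place of isobutyl on a sulfonamide nitrogen with cyclopentyl in place of isobutyl on a sulfonamide nitrogen. Among the compounds with values here, no measured pair shows the effect of a change at this place, so no step beyond the scatter is expected in this assay in either direction. The expected result is a 1.2-fold lower number from compound 2 to compound 4 (0.06 log units; within the scatter) as an estimated step within the scatter. For compound 4 the estimated value is 600 nM with an expected range from 250 nM to 1400 nM around that estimate.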

Compound 4, half-maximal inhibitory concentration: 3300 nM
For compound 4 the middle estimate is 5.5-fold (0.74 log units) below the measured one, and the stated range ends below it.
By their numbers in this assay, from the lowest: compounds 1 and 2 (each within the scatter of the next); then compound 3; then compound 4.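

In this assay, the group on the sulfonamide nitrogen proves not to be indifferent: cyclopentyl in place of isobutyl gives a 4.8-fold higher number from compound 2 to compound 4 (0.68 log units; beyond the scatter). Within the data shown here, this is the first comparison that differs in one place only, and the earlier compounds could not separate the contribution of this group from changes elsewhere. On the core of compound 2, the exchange of an open four-carbon group for a five-membered carbon ring therefore costs activity in these cells, but no accompanying measurement explains the step.

Still open, as far as these compounds go, is whether the step follows the ring itself or the additional carbon. A cyclopropyl ring or a straight pentyl chain on the same nitrogen, on the core of compound 2, would bear on that question.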